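The source may hold more compounds than are shown below. What is called first, only, known or untested is meant among the compounds shown, and "the series" means these compounds.

Working notes on the series. Three compounds have numbers in an ADME assay on MRC5 cells (Homo sapiens) for inhibition, with a stated time of 72 h; on this read-out higher numbers stand for an effect only at larger amounts of compound and lower numbers for an effect already at smaller amounts. Compound 1 `COc1cccc(OC)c1C(=O)Nc1c[nH]nc1C(=O)NC1CCCCCC1` gives 42000 nM in this assay, the highest of the three. Compound 2 `CO[C@H]1CC[C@H](NC(=O)c2n[nH]cc2NC(=O)c2ccc(N3CCN(C)CC3)cc2)CC1` gives 20000 nM, and compound 3 `CO[C@H]1CC[C@H](NC(=O)c2n[nH]cc2NC(=O)c2ccccc2)CC1` gives 800 nM. Compound 1 stands beyond the scatter of compound 2 and far above compound 3. Among the measured compounds shown here, the one step with both ends measured is a 25-fold lower number from compound 2 to compound 3 (1.40 log units; beyond the scatter); it concerns a substituent on an aromatic carbon and lies beyond the scatter.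

Compound 4 `COc1cccc(OC)c1C(=O)Nc1c[nH]nc1C(=O)NC1CCC1` differs from compound 1 at the amide nitrogen only: cyclobutyl in place of cycloheptyl on an amide-type nitrogen. For the measured compounds named here, no measured pair in this set alters the ring on that nitrogen; the step from compound 2 to compound 3 changes the aromatic part and gives no reading on the ring carried by the amide nitrogen. The data hold nothing that would point to a shift in either direction for this change, so the expected step from compound 1 to compound 4 is one within the scatter, a 1.1-fold lower number from compound 1 to compound 4 (0.02 log units; within the scatter). Going by the values given here, for compound 4 the estimated value in this assay is 40000 nM, with a range from 15000 nM to 110000 nM; the range is wide since no measured step informs it.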

Compound 4, half-maximal effective concentration: > 50000 nM
Compound 4: only a limit was reported; the forecaster's own chance of this, stated with the estimate: 25%; middle value at least 1.2-fold (0.09 log units) from the limit.
By their numbers in this assay, from the lowest: compound 3; then compound 2; then compound 1. At a limit, above all of these: compound 4.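

Among the compounds shown here, this is the first reading on the ring carried by the amide nitrogen: in this assay, cyclobutyl in place of cycloheptyl gives an at least 1.1-fold higher number from compound 1 to compound 4 (0.07 log units; that floor lies within the scatter). Compound 4 stands at a limit of the assay, > 50000 nM, so this step gives a floor and no size. On the core of compound 1, the smaller ring on this nitrogen gives no lower number, and how far the number for compound 4 lies upward cannot be read from the one value at the limit: the limit of > 50000 nM in this assay, at which 1 of the 4 values shown sits.

As far as these compounds go, only cycloheptyl and cyclobutyl are compared on this nitrogen with the core of compound 1, so it remains open how a cyclopentyl ring, a piperidine ring carrying a basic amine, or an open butyl chain would read in this assay. Also open, from the compounds shown here alone, is whether the aromatic change behind a 25-fold lower number from compound 2 to compound 3 (1.40 log units; beyond the scatter) would carry over to the core of compound 1, where the amide nitrogen bears cycloheptyl or cyclobutyl.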